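Lengthening the acid chain on the aniline of compound 2

The compounds below may be only part of what the source reports. "The series", "measured", "known", "first", "only" and "open" are said of these compounds alone.

Within the data shown here, compound 2 `O=C(O)c1ccc(NCc2cccc(Oc3ccccc3)c2)cc1` is one of three compounds measured in a functional assay on CHO cells for agonist activity at Free fatty acid receptor 1 (Homo sapiens); a higher number here means that more compound is needed for the effect, a lower number that less compound is needed. For compound 2 the assay returned only a limit, < 10000 nM. The same limit, (the limit of < 10000 nM in this assay, at which 2 of the 3 values shown sit), is shared by compound 3 `Cc1nc(-c2ccc(C(F)(F)F)cc2)sc1CNc1ccc(CC(=O)O)cc1`, which in this assay gives < 10000 nM. Compound 1 `Cc1nc(-c2ccc(C(F)(F)F)cc2)sc1CNc1ccc(CCC(=O)O)cc1` differs from compound 3 only in the acid chain, and in this assay compound 1 gives 67.6 nM. The step that the limit leaves unreadable from compound 1 to compound 3 cannot be sized, but it does show that the shorter chain on the core of compound 1 falls to the limit while the longer one gives a readable number.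

Compound 4 `O=C(O)CCCc1ccc(NCc2cccc(Oc3ccccc3)c2)cc1` differs from compound 2 by 3-carboxypropyl in place of carboxy on an aromatic carbon, a change in the same spirit, extending the acid away from the ring by three more carbons rather than by one. Among the measured compounds shown here, no measured step covers compound 2 and compound 4 directly, and since compound 2 sits at a limit the step to compound 4 can only be expected as a gain of unreadable size. On that basis compound 4 is estimated at 700 nM, within 120 nM to 6000 nM, which would mean an expected step that the limit leaves unreadable from compound 2 to compound 4.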

Compound 4, half-maximal effective concentration: 1120 nM
The estimate for compound 4 lay 1.6-fold (0.20 log units) below the measured number; the range from low to high includes it.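

Compound 2 gives only a limit of the assay, so no size can be read for its step to compound 4: the limit of < 10000 nM in this assay, at which 2 of the 4 values shown sit.

The compounds shown leave open how much of the activity of compound 4 depends on the length of its 3-carboxypropyl chain, and whether that chain would behave alike on the core of compound 1.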